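Lengthening an ether chain on a sulfonamide series

The source may hold more compounds than are shown below. What is called first, only, known or untested is meant among the compounds shown, and "the series" means these compounds.

Of the compounds shown here, three sharing one core have been measured in an assay on CHO cells for displacement of a labelled ligand from prostaglandin E2 receptor EP1 subtype (Homo sapiens); a higher number here means a weaker inhibitor, a lower number a stronger inhibitor. Compound 1 `CCOc1ccc(Cc2nnc(CN(c3ccccc3CC)S(=O)(=O)c3ccc(C)cc3)o2)cc1` gives 126 nM, compound 2 `CCOc1ccc(Cc2nnc(CN(c3cccc(Cl)c3C)S(=O)(=O)c3ccc(C)cc3)o2)cc1` gives 3.98 nM, and compound 3 `COc1ccc(Cc2nnc(CN(c3cccc(Cl)c3Cl)S(=O)(=O)c3ccc(C)cc3)o2)cc1` gives 7.94 nM. Compound 3 thus stands second highest of the three numbers, close to compound 2 and far below compound 1. Within the data shown here, the one single-point step measured, a 32-fold lower number from compound 1 to compound 2 (1.50 log units; beyond the scatter), changes the group on the sulfonamide nitrogen, not the part altered here. Compound 4 `CCOc1ccc(Cc2nnc(CN(c3cccc(Cl)c3Cl)S(=O)(=O)c3ccc(C)cc3)o2)cc1` differs from compound 3 by methyl in place of hydrogen on a saturated chain carbon bound to an oxygen on an aromatic ring. Among the measured compounds shown here, no measured step touches that site, so the change is expected to produce no shift beyond the scatter, a step of a 1.3-fold lower number from compound 3 to compound 4 (0.10 log units; within the scatter). Compound 4 is therefore estimated at 6.3 nM, within a range of 2.5 nM to 16 nM.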

Compound 4, half-maximal inhibitory concentration: 6.31 nM
Estimate against measurement, compound 4: 1.0-fold (0.00 log units) below; low and high end bracket the measured number.
By their numbers in this assay, from the lowest: compounds 2, 4 and 3 (each within the scatter of the next); then compound 1.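

Within this assay, going from methoxy to ethoxy on this saturated chain (a 1.3-fold lower number from compound 3 to compound 4 (0.10 log units; within the scatter)) shows that this site accepts the added methyl without a shift beyond the scatter. With ethoxy in place, chloro in place of methyl on an aromatic carbon also stays within the scatter (a 1.6-fold higher number from compound 2 to compound 4 (0.20 log units; within the scatter)), whereas 2,3-dichlorophenyl in place of 2-ethylphenyl on the sulfonamide nitrogen remains a large change (a 20-fold lower number from compound 1 to compound 4 (1.30 log units; beyond the scatter)). Nothing available explains these results. On these data alone, whether a longer chain, such as butoxy, or a chain ending in an amine would keep these numbers remains open.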